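The source may hold more compounds than are shown below. What is called first, only, known or untested is meant among the compounds shown, and "the series" means these compounds.

Compound 2 `CCCCN1CCC(Oc2ccc3c(C)c(C)c(=O)oc3c2)CC1` gives 1410 nM in an assay for inhibition of Amine oxidase [flavin-containing] B (Homo sapiens), read by fluorescence, using microsomes, with stated times of 20 min and 30 min (on this read-out higher numbers stand for weaker inhibition and lower numbers for stronger inhibition), the highest of the two numbers recorded so far. Compound 1 `Cc1c(C)c2ccc(OC3CCN(C)CC3)cc2oc1=O`, which gives 274 nM in this assay, is its nearest neighbour, and the step of a 5.1-fold higher number from compound 1 to compound 2 (0.71 log units; beyond the scatter) separates the two. Compound 3 `Cc1c(C)c2ccc(OC3CCN(Cc4ccccc4)CC3)cc2oc1=O` has not yet been measured. Its difference from compound 2 is phenyl in place of propyl on a saturated chain carbon bound to an amine nitrogen in a ring. Among the compounds with values here, only one measured step bears on this change, a 5.1-fold higher number from compound 1 to compound 2 (0.71 log units; beyond the scatter), and it concerns a different alteration at the same place, so it says little about the exchange of propyl for phenyl. Within the data shown here, with no closer precedent in these data, no step beyond the scatter is expected in either direction, although the uncertainty is wide. Compound 3 is therefore estimated at 1100 nM, with a range from 300 nM to 4000 nM, which means an expected step of a 1.3-fold lower number from compound 2 to compound 3 (0.11 log units; within the scatter) that stays within the scatter.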

Compound 3, half-maximal inhibitory concentration: 445 nM
Beside the measured number, compound 3's estimate is 2.5-fold (0.39 log units) above it; the measured number falls inside the stated range.
By their numbers in this assay, from the lowest: compounds 1 and 3 (each within the scatter of the next); then compound 2.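

The change at this place is not a simple matter of adding atoms to the amine nitrogen: phenyl carries more heavy atoms than propyl, yet the exchange gives a 3.2-fold lower number from compound 2 to compound 3 (0.50 log units; beyond the scatter) in this assay. The higher number seen with the butyl group of compound 2 therefore does not carry over to the benzyl group of compound 3. The benzyl group is also accommodated with little penalty, since the comparison with the methyl compound gives a 1.6-fold higher number from compound 1 to compound 3 (0.21 log units; within the scatter) and so shows no change beyond the scatter. Nothing shown explains why the two groups differ at this place.

The compounds shown leave open whether the aromatic ring itself matters, which a cyclohexylmethyl group on the same nitrogen would address. They also leave open how substituents on the phenyl ring, such as a fluorine or a methoxy group, or a longer chain ending in phenyl, would read here.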